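A Methyl Step on Compound 1

This account rests on a few compounds, and the source may have more. Where it says the series, first, only, none or still open, it means among the compounds named here.

Measured in an ADME assay on MT4 cells (Homo sapiens) for cytotoxicity, read by MTT assay; on this read-out lower numbers stand for higher toxicity in this test and higher numbers for lower toxicity in this test:
- compound 1 `O=C1c2ccccc2C(=O)N1CCOC(=S)N(C(=O)c1cccc([N+](=O)[O-])c1)c1ccc(Cl)cc1`: 18000 nM
- compound 2 `O=C1c2ccccc2C(=O)N1CCOC(=S)N(C(=O)c1cc(F)ccc1F)c1ccc(Cl)cc1`: 54000 nM
- compound 3 `O=C1c2ccccc2C(=O)N1CCOC(=S)N(C(=O)c1ccc(Cl)c(Cl)c1)c1ccc(Cl)cc1`: 35000 nM

For the measured compounds named here, compound 1 stands at the low end of this small set, though only one of its two comparisons clears the scatter. The first is a 3.0-fold higher number from compound 1 to compound 2 (0.48 log units; beyond the scatter), and the second is a 1.9-fold higher number from compound 1 to compound 3 (0.29 log units; within the scatter). The remaining comparison is a 1.5-fold lower number from compound 2 to compound 3 (0.19 log units; within the scatter).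

Compound 4 `Cc1ccc2c(c1)C(=O)N(CCOC(=S)N(C(=O)c1cccc([N+](=O)[O-])c1)c1ccc(Cl)cc1)C2=O` keeps the whole of compound 1 apart from one change: methyl in place of hydrogen on an aromatic carbon. In words, this is methyl in place of hydrogen on an aromatic carbon. Going by the values given here, no measured step touches that place, since all three exchange the group on a carbonyl carbon, so they bear on it only indirectly. They show that even those larger exchanges moved the number modestly at most in this assay, the widest being a 3.0-fold higher number from compound 1 to compound 2 (0.48 log units; beyond the scatter). A change of one methyl group is therefore expected to produce no step beyond the scatter, with no firm direction. The expected result is a 1.2-fold higher number from compound 1 to compound 4 (0.09 log units; within the scatter). For compound 4 the estimated value is 22000 nM, with an expected range from 10000 nM to 50000 nM.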

Compound 4, half-maximal cytotoxic concentration: > 100000 nM
Compound 4 was reported as a limit (the forecaster's own chance of this, stated with the estimate: 10%); at least 4.5-fold (0.65 log units) between middle value and limit.
By their numbers in this assay, from the lowest: compounds 1, 3 and 2 (each within the scatter of the next, the first and the last beyond it). At a limit, above all of these: compound 4.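

In this assay, a single methyl in place of hydrogen on an aromatic carbon gave a larger step than any exchange on the carbonyl carbon, with an at least 5.5-fold higher number from compound 1 to compound 4 (0.74 log units; beyond the scatter). Compound 4 is reported only as a limit of the assay, > 100000 nM, and not as a number, so the step has a floor but no known size: the limit of > 100000 nM in this assay, at which 1 of the 4 values shown sits. The earlier compounds shown here varied only the group on the carbonyl carbon, whereas this result shows that the number also responds to a change on the six-membered aromatic ring of carbon only, part of a fused or bridged system of two rings, and here it moved toward lower toxicity in this test.

From the compounds shown here alone, this finding rests on one methyl in one compound, so it remains open whether a chlorine, a methoxy group or a longer chain on the same carbon would move the number in the same way. Going by these compounds, it is also open whether the methyl would have a similar effect with the 2,5-difluorophenyl of compound 2 or the 3,4-dichlorophenyl of compound 3 on the carbonyl carbon.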